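Hydrazone series: varying the aryl group on the carbonyl carbon

The source may report more compounds than this note shows. Statements on the series, on what has been measured and on what is new or still open speak of the compounds shown alone.

Two members of the series have been measured in a functional assay on MDA-MB-231 cells (Homo sapiens) for antiproliferative activity, with a stated time of 4 days; on this read-out higher numbers stand for weaker inhibition and lower numbers for stronger inhibition. Compound 1 `CCCCc1ccc2[nH]c(-c3ccc(OC)cc3)c(/C=N/NC(=O)c3ccc(Cl)cc3)c2c1` gives 90 nM in this assay. Compound 2 `CCCCc1ccc2[nH]c(-c3ccc(OC)cc3)c(/C=N/NC(=O)c3cccc(OC)c3)c2c1`, which carries 3-methoxyphenyl in place of 4-chlorophenyl on the carbonyl carbon, gives 55 nM in this assay. That single step, a 1.6-fold lower number from compound 1 to compound 2 (0.21 log units; within the scatter), is the only one recorded so far, and it falls within the scatter of the measurement. Compound 2 therefore holds the lowest of the two numbers, but its nearest neighbour, compound 1, sits within the scatter of it, so no order between the two can be claimed.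

Compound 3 `CCCCc1ccc2[nH]c(-c3ccc(OC)cc3)c(/C=N/NC(=O)c3ccc([N+](=O)[O-])cc3)c2c1` is the next member and has yet to be measured in this assay. Relative to compound 2, the change is 4-nitrophenyl in place of 3-methoxyphenyl on a carbonyl carbon. Within the data shown here, the one step that bears on it is the exchange at the same carbonyl carbon from compound 1 to compound 2, and that step was within the scatter. On that basis the step of a 1.5-fold higher number from compound 2 to compound 3 (0.16 log units; within the scatter) is expected to stay within the scatter as well, with no direction favoured. Compound 3 is estimated at 80 nM in this assay, within a range of 30 nM to 250 nM.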

Compound 3, half-maximal inhibitory concentration: 115 nM
Beside the measured number, compound 3's estimate is 1.4-fold (0.16 log units) below it, within the range that was stated.
By their numbers in this assay, from the lowest: compounds 2, 1 and 3 (each within the scatter of the next, the first and the last beyond it).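

In this assay, the exchange at the carbonyl carbon now gives its first step beyond the scatter (a 2.1-fold higher number from compound 2 to compound 3 (0.32 log units; beyond the scatter)), so 3-methoxyphenyl and 4-nitrophenyl at this place can be told apart, though only modestly. Nitro in place of chloro on an aromatic carbon (a 1.3-fold higher number from compound 1 to compound 3 (0.11 log units; within the scatter)) stays within the scatter, so compound 1 and compound 3 cannot be ordered, and compound 1 also remains within the scatter of compound 2. Nothing at hand explains either step.

The step from 3-methoxyphenyl to 4-nitrophenyl changes both the group and its place on the ring, so it cannot be assigned to either change alone, and a 4-methoxyphenyl or 3-nitrophenyl group on the carbonyl carbon would be needed to separate the two. Also open is whether an aminophenyl or carboxyphenyl group at this place would move the number further than the aryl groups shown, and what a shorter chain in place of the butyl chain on the shared core would do.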